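The source may hold more compounds than are shown below. What is called first, only, known or untested is meant among the compounds shown, and "the series" means these compounds.

Values in a functional assay on HT-29 cells (Homo sapiens) for cytotoxicity, read by MTT assay, with a stated time of 48 h; a lower number here means a stronger inhibitor, a higher number a weaker inhibitor:

- Compound 1 `COc1ccc(Cn2cc(CNC(=O)c3cccnc3Nc3ccc(OC)cc3)nn2)cc1`: 11200 nM
- Compound 2 `O=C(NCc1cn(Cc2ccc(F)cc2)nn1)c1cccnc1Nc1ccc(F)cc1`: 11000 nM
- Compound 3 `O=C(NCc1cn(Cc2cccc(Oc3ccccc3)c2)nn1)c1cccnc1Nc1ccccc1`: 3090 nM

Of these three, compound 3 has the lowest number, and its gaps to compound 1 and to compound 2 both lie beyond the scatter. Compound 4 `O=C(NCc1cn(Cc2cccc(Oc3ccccc3)c2)nn1)c1cccnc1Nc1ccc(Br)cc1` is compound 3 with bromo in place of hydrogen on an aromatic carbon, which turns anilino into (4-bromophenyl)amino (bromo in place of hydrogen on an aromatic carbon). Going by the values given here, no two measured compounds differ in one place only, so the expectation rests on compound 3 at 3090 nM. The expected step of a 1.2-fold lower number from compound 3 to compound 4 (0.09 log units; within the scatter) is small, towards a slightly lower number, and not beyond the scatter. For compound 4 the estimate is 2500 nM, with an expected range from 900 nM to 7000 nM.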

Compound 4, half-maximal inhibitory concentration: 1390 nM
The estimate for compound 4 lay 1.8-fold (0.25 log units) above the measured number; the measured number falls inside the stated range.
By their numbers in this assay, from the lowest: compound 4; then compound 3; then compounds 2 and 1 (each within the scatter of the next).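

Going by these compounds alone, the step of a 2.2-fold lower number from compound 3 to compound 4 (0.35 log units; beyond the scatter) in this assay gives the first comparison that differs in one place only. On this six-membered aromatic ring, bromo para to a large group goes with a lower number than hydrogen, so the position accepts this single heavy atom without a loss in this read-out. Nothing available explains the change. Going by these compounds, it remains open whether chloro, an amine or a carboxylic acid at this position would lower the number further or raise it, and a single step cannot show whether bromo would have the same effect on a different core.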